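A few compounds are considered here, and "the series" means these few. Any claim that something is new, unique, unknown or untested is made for them only; others in the source may bear on it.

Measured compounds in this series:
compound 1 `Cc1cc(Br)ccc1NC(=O)COc1ccc2cc(/C=C3/SC(=O)NC3=O)ccc2c1` — 7400 nM in an assay on isolated protein for inhibition of histone deacetylase 8 (Homo sapiens), with a stated time of 1 h; on this read-out lower numbers stand for stronger inhibition and higher numbers for weaker inhibition
compound 2 `Cc1cccc2sc(NC(=O)COc3ccc4cc(/C=C5/SC(=O)NC5=O)ccc4c3)nc12` — compound 2 gives 5800 nM
compound 3 `Cc1ccc(NC(=O)COc2ccc3cc(/C=C4/SC(=O)NC4=O)ccc3c2)cc1Cl` — compound 3 reaches only the assay limit, > 50000 nM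

Compound 3 therefore sits at the limit of > 50000 nM in this assay, at which 1 of the 3 values shown sits, and has no number of its own in this assay. The steps of an at least 6.7-fold higher number from compound 1 to compound 3 (0.82 log units; beyond the scatter) and an at least 8.6-fold higher number from compound 2 to compound 3 (0.93 log units; beyond the scatter) both place compound 3 beyond the scatter weaker than the other two amide substituents; the step of a 1.3-fold lower number from compound 1 to compound 2 (0.11 log units; within the scatter) stays within the scatter.

Compound 4 `O=C(COc1ccc2cc(/C=C3/SC(=O)NC3=O)ccc2c1)Nc1ccc(Br)cc1` carries the change (4-bromophenyl in place of 3-chloro-4-methylphenyl on an amide-type nitrogen). Compound 4 shares the bromine-bearing phenyl of compound 1, which gave 7400 nM, so the estimated step of an at least 4.1-fold lower number from compound 3 to compound 4 (0.61 log units; beyond the scatter) is expected to run toward stronger inhibition. Compound 4 is expected to give 12000 nM, between 4000 nM and 50000 nM.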

Compound 4, half-maximal inhibitory concentration: 16000 nM
Compound 4: middle estimate off by 1.3-fold (0.12 log units), on the low side, within the range that was stated.
By their numbers in this assay, from the lowest: compounds 2 and 1 (each within the scatter of the next); then compound 4. At a limit, above all of these: compound 3.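

On the amide-type nitrogen, 4-bromophenyl in place of 3-chloro-4-methylphenyl gives an at least 3.1-fold lower number from compound 3 to compound 4 (0.49 log units; beyond the scatter) and so returns a measurable number on a simple substituted phenyl. Hydrogen in place of methyl on an aromatic carbon gives a 2.2-fold higher number from compound 1 to compound 4 (0.33 log units; beyond the scatter) and, with a 2.8-fold higher number from compound 2 to compound 4 (0.44 log units; beyond the scatter) on the same nitrogen, places compound 4 modestly weaker than both other measured amides. Compound 3 remains a limit, not a number: the limit of > 50000 nM in this assay, at which 1 of the 4 values shown sits.

On these data alone, how an unsubstituted phenyl, or a phenyl carrying an amine or a carboxylic acid, would read on this nitrogen stays open. So does the true size of the step to compound 4 from compound 3.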